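Swapping a Cyclic Amide for a Simple Amino Group

This account rests on a few compounds, and the source may have more. Where it says the series, first, only, none or still open, it means among the compounds named here.

Measured so far:
Compound 1 `Cc1ccc(-c2cc(Cl)ccc2OCc2ccc(F)cc2)n1-c1cc(NS(C)(=O)=O)cc(C(=O)O)c1` gives 1.59 nM
Compound 2 `Cc1ccc(-c2cc(Br)ccc2OCc2ccc(F)cc2F)n1-c1cc(C(=O)O)cc(N2CCCCC2=O)c1` gives 1.26 nM
Compound 3 `Cc1ccc(-c2cc(Br)ccc2OCc2ccc(F)cc2F)n1-c1cc(C(=O)O)cc(N2CCCC2=O)c1` gives 2 nM

All three numbers come from an assay on CHO cells for displacement of a labelled ligand from prostaglandin E2 receptor EP1 subtype (Homo sapiens); a lower number here means a stronger inhibitor, a higher number a weaker inhibitor. Compound 3 stands at 2 nM, and compound 1 and compound 2 both sit within the usual scatter of it, so the three cannot be told apart on these numbers.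

Compound 4 `Cc1ccc(-c2cc(Br)ccc2OCc2ccc(F)cc2F)n1-c1cc(N)cc(C(=O)O)c1` is the next step from compound 3: amino in place of 2-oxopyrrolidin-1-yl on an aromatic carbon. Within the data shown here, the one measured step that bears on this place is a 1.6-fold higher number from compound 2 to compound 3 (0.20 log units; within the scatter), where the ring of the cyclic amide was shrunk by one carbon and the number stayed within the scatter. That step kept an amide ring at this place, whereas compound 4 removes the ring entirely and leaves only a small amino group, a much larger change than anything measured here. Compound 1, which differs from compound 3 in more than one place, also sits within the scatter of compound 3.

With the ring gone, compound 4 is expected to give a somewhat higher number, a step of a 2.0-fold higher number from compound 3 to compound 4 (0.30 log units; within the scatter). The estimate for compound 4 in this assay is 4 nM, with a range from 1.5 nM to 12 nM.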

Compound 4, half-maximal inhibitory concentration: 0.501 nM
Beside the measured number, compound 4's estimate is 8.0-fold (0.90 log units) above it, and the stated range ends above it.
By their numbers in this assay, from the lowest: compound 4; then compounds 2, 1 and 3 (each within the scatter of the next).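

In this assay, the cyclic amide at this place on the aromatic ring proves dispensable, since the plain amino group gives a 4.0-fold lower number from compound 3 to compound 4 (0.60 log units; beyond the scatter) in place of 2-oxopyrrolidin-1-yl and a 2.5-fold lower number from compound 2 to compound 4 (0.40 log units; beyond the scatter) in place of 2-oxopiperidin-1-yl. Among these compounds, both steps are modest but lie beyond the scatter, whereas the only earlier step at this place, a 1.6-fold higher number from compound 2 to compound 3 (0.20 log units; within the scatter), stayed within it, so this position now shows for the first time a difference that can be told from noise. No evidence is available to explain why the smaller group gives the lower number.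

Going by these compounds, it remains open whether a methylamino, dimethylamino or acetylamino group here would keep the lower number. On these data alone, whether the amino group would have the same effect on a different core also remains open.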